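From 4-ethoxyphenyl to anilino on the shared core

A few compounds are considered here, and "the series" means these few. Any claim that something is new, unique, unknown or untested is made for them only; others in the source may bear on it.

In a functional assay on Jurkat cells (Homo sapiens) for antiproliferative activity, read by MTT assay, with a stated time of 72 h (on this read-out lower numbers stand for stronger inhibition and higher numbers for weaker inhibition), compound 1 `COc1ccccc1-c1c(C(=O)c2cc(OC)c(OC)c(OC)c2)sc2ccccc12` gives 2900 nM and compound 3 `CCOc1ccc(-c2c(C(=O)c3cc(OC)c(OC)c(OC)c3)sc3ccccc23)cc1` gives 4100 nM. The two are not separated, as a 1.4-fold higher number from compound 1 to compound 3 (0.15 log units; within the scatter) shows. Compound 2 `COc1ccc(-c2c(C(=O)c3cc(OC)c(OC)c(OC)c3)sc3ccccc23)cc1C` is reported only as a limit, > 10000 nM. Compound 3 thus sits level with compound 1 and clear of compound 2, with an at least 2.4-fold lower number from compound 2 to compound 3 (0.38 log units; beyond the scatter).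

Compound 4 `COc1cc(C(=O)c2sc3ccccc3c2Nc2ccccc2)cc(OC)c1OC` comes from compound 3 by a single exchange, anilino in place of 4-ethoxyphenyl on an aromatic carbon of the five-membered ring with 1 sulfur. For the measured compounds named here, no measured step makes this exchange, so the evidence is indirect. The nearest guides are the other changes of group at the same carbon. There, a 1.4-fold higher number from compound 1 to compound 3 (0.15 log units; within the scatter) stayed within the scatter, while an at least 3.4-fold higher number from compound 1 to compound 2 (0.53 log units; beyond the scatter) went beyond it. These two steps leave the direction open and allow a sizeable move towards weaker inhibition, so the range has to be wide. Taking compound 3 at 4100 nM as the anchor, no step beyond the scatter is expected, and the expected step is a 1.0-fold lower number from compound 3 to compound 4 (0.01 log units; within the scatter). Compound 4 is estimated at 4000 nM, with an expected range from 900 nM to 10000 nM.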

Compound 4, half-maximal inhibitory concentration: 1600 nM
For compound 4 the middle estimate is 2.5-fold (0.40 log units) above the measured one; the measured number falls inside the stated range.
By their numbers in this assay, from the lowest: compounds 4, 1 and 3 (each within the scatter of the next, the first and the last beyond it). At a limit, above all of these: compound 2.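

In this assay, for the compounds shown here, anilino in place of 4-ethoxyphenyl gives a 2.6-fold lower number from compound 3 to compound 4 (0.41 log units; beyond the scatter), so this carbon of the five-membered aromatic ring with 1 sulfur accepts a group that enters with 1 hydrogen-bond donor and still keeps one six-membered aromatic ring of carbon only; among the earlier compounds, the only step towards stronger inhibition started from compound 2. The gain is not general across the groups at this carbon, for a 1.8-fold lower number from compound 1 to compound 4 (0.26 log units; within the scatter) leaves anilino level with the 2-methoxyphenyl of compound 1. The widest gap also starts from compound 2, and an at least 6.2-fold lower number from compound 2 to compound 4 (0.79 log units; beyond the scatter) gives only a lower bound on its size, as compound 2 is reported as a limit: the limit of > 10000 nM in this assay, at which 1 of the 4 values shown sits.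

The exchange changes the atom attached to the carbon and removes the ethoxy group together, so the compounds shown leave open which of these changes goes with the lower number. An N-methylanilino group would test the role of the amine hydrogen, while a 4-ethoxyanilino or 2-methoxyanilino group would show whether the ring substituents of compounds 3 and 1 can be combined with the amine link.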